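Bromo for chloro on two cores

The source may hold more compounds than are shown below. What is called first, only, known or untested is meant among the compounds shown, and "the series" means these compounds.

In a functional assay on HeLa cells (Homo sapiens) for inhibition, read by MTT assay, with a stated time of 48 h (on this read-out lower numbers stand for stronger inhibition and higher numbers for weaker inhibition), the measured compounds stand as follows:
compound 1 `Clc1ccc(C(c2c[nH]c3ccc(Br)cc23)c2c[nH]c3ccc(Br)cc23)cc1` gives 4800 nM
compound 2 `Brc1ccc(C(c2c[nH]c3ccc(Br)cc23)c2c[nH]c3ccc(Br)cc23)cc1` gives 1500 nM
compound 3 `O=[N+]([O-])c1ccc2[nH]cc(C(c3ccc(Cl)cc3)c3c[nH]c4ccc([N+](=O)[O-])cc34)c2c1` gives only a limit of the assay, > 100000 nM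

Compound 1 and compound 2 differ by bromo in place of chloro on an aromatic carbon. That change gave a 3.2-fold lower number from compound 1 to compound 2 (0.51 log units; beyond the scatter). Compound 3 carries a different core; the difference between the two cores is not broken down here. The value for compound 3 is a limit, not a number, and in this assay (the limit of > 100000 nM in this assay, at which 1 of the 3 values shown sits).

Compound 4 `O=[N+]([O-])c1ccc2[nH]cc(C(c3ccc(Br)cc3)c3c[nH]c4ccc([N+](=O)[O-])cc34)c2c1` has not yet been measured. It differs from compound 3 by bromo in place of chloro on an aromatic carbon, the same change, at the same place, that turned compound 1 into compound 2. The change is expected to help by about as much as it helped before, but compound 3 starts from a limit, so no number can anchor the step. Compound 4 is therefore expected to reach 100000 nM, within 30000 nM and 300000 nM, which means an expected a number no higher from compound 3 to compound 4 (the limit leaves the size open), with a fair chance that this assay again reports only a limit.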

Compound 4, half-maximal inhibitory concentration: > 100000 nM
Compound 4 was reported as a limit (the forecaster's own chance of this, stated with the estimate: 65%); the middle value sits exactly at the limit.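

In this assay, compound 3 and compound 4 are both reported only as limits, so no step can be read between them: the limit of > 100000 nM in this assay, at which 2 of the 4 values shown sit.

From the compounds shown here alone, it remains open whether bromo in place of chloro on the core of compound 3 gives anything like a 3.2-fold lower number from compound 1 to compound 2 (0.51 log units; beyond the scatter), or any change at all.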